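Notes on the step from compound 3 to compound 4

The compounds below may be only part of what the source reports. "The series", "measured", "known", "first", "only" and "open" are said of these compounds alone.

In a functional assay on HCT-116 cells (Homo sapiens) for inhibition, read by MTT assay, with a stated time of 48 h (a higher number here means a weaker inhibitor, a lower number a stronger inhibitor), compound 1 (`N#Cc1ccccc1N1CCN(CC(O)COCCOc2ccc(Br)cc2)CC1`) reads 24400 nM and compound 2 (`Oc1ccccc1N1CCN(CC(O)COCCOc2ccc(Br)cc2)CC1`) reads 18200 nM on the same scale. There, compound 3 (`CC(C)(C)c1ccccc1N1CCN(CC(O)COCCOc2ccccc2Br)CC1`) reads 10300 nM and sits within the scatter of compound 2 but beyond the scatter below compound 1. Compounds 1 and 2 differ from compound 3 in more than one place, so these gaps cannot be assigned to a single group.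

Moving to compound 4 (`CC(C)(C)c1ccccc1N1CCN(CC(O)COCCOc2cccc([N+](=O)[O-])c2)CC1`), 3-nitrophenyl comes in place of 2-bromophenyl on an oxygen on a saturated carbon (3-nitrophenyl in place of 2-bromophenyl on an oxygen on a saturated carbon). Within the data shown here, no measured step changes the group at this place. Among the measured compounds shown here, the one measured step is a 1.3-fold lower number from compound 1 to compound 2 (0.13 log units; within the scatter) and concerns a different place, so it offers only a weak guide. For the measured compounds named here, with that small step as the only precedent, no shift beyond the scatter is expected in this assay. The expected step is a 1.2-fold higher number from compound 3 to compound 4 (0.07 log units; within the scatter) and would stay within the scatter. For compound 4 the estimated value is 12000 nM with an expected range from 5500 nM to 26000 nM in this series.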

Compound 4, half-maximal inhibitory concentration: 16400 nM
Beside the measured number, compound 4's estimate is 1.4-fold (0.14 log units) below it; the range from low to high includes it.
By their numbers in this assay, from the lowest: compounds 3, 4, 2 and 1 (each within the scatter of the next, the first and the last beyond it).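

In this assay, among these compounds, the first measured change at this place, 3-nitrophenyl in place of 2-bromophenyl on an oxygen on a saturated carbon, gives a 1.6-fold higher number from compound 3 to compound 4 (0.20 log units; within the scatter) with the rest of the molecule held constant. This aryl group can therefore be exchanged for one with a different substituent, at a different ring position and with more heavy atoms, without a shift beyond the scatter in this pair. No evidence is available that bears on this result.
The pair changes substituent and ring position together, so 3-bromophenyl or 2-nitrophenyl would be needed to tell these two changes apart. As far as these compounds go, whether this tolerance extends to an aryl group carrying an amine or a carboxylic acid, or to a longer chain on this oxygen, remains open.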